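The source may report more compounds than this note shows. Statements on the series, on what has been measured and on what is new or still open speak of the compounds shown alone.

In an ADME assay on the whole organism for pharmacokinetics, with Mus musculus as the target, at a dose of 10 mg/kg by the oral route (on this read-out lower numbers stand for lower exposure and higher numbers for higher exposure at the dose given), compound 1 (`CC/C(=C(/c1ccc(/C=C/C(=O)O)cc1)c1ccc2[nH]c(=O)oc2c1)c1ccccc1`) gives 3000 ng.h/mL and compound 2 (`CC/C(=C(/c1ccc(/C=C/C(=O)O)cc1)c1cccc2[nH]ncc12)c1ccccc1`) gives 2800 ng.h/mL. Compound 3 (`CC/C(=C(/c1ccc(/C=C/C(=O)O)cc1)c1ccc2[nH]ncc2c1)c1ccccc1C#N`) is the lowest of the three at 200 ng.h/mL, beyond the scatter from both others. Compound 4 (`CC/C(=C(/c1ccc(/C=C/C(=O)O)cc1)c1ccc2[nH]ncc2c1)c1ccncc1Cl`) carries 3-chloropyridin-4-yl in place of 2-cyanophenyl on a double-bonded chain carbon bound to a double-bonded chain carbon and a saturated chain carbon. For the measured compounds named here, no measured step covers this change. The only one, a 1.1-fold lower number from compound 1 to compound 2 (0.03 log units; within the scatter), lies within the scatter and concerns another group, so it offers little guidance. Compound 2 at 2800 ng.h/mL shows room above compound 3, so a moderate rise is expected, though with wide uncertainty. The estimated change is expected to be a 3.5-fold higher number from compound 3 to compound 4 (0.54 log units; beyond the scatter). Compound 4 is estimated at 700 ng.h/mL, with an expected range of 150 ng.h/mL to 3000 ng.h/mL.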

Compound 4, area under the concentration-time curve: 110 ng.h/mL
Compound 4: middle estimate off by 6.4-fold (0.80 log units), on the high side, and the stated range ends above it.
By their numbers in this assay, from the lowest: compounds 4 and 3 (each within the scatter of the next); then compounds 2 and 1 (each within the scatter of the next).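

Exchanging 2-cyanophenyl for 3-chloropyridin-4-yl on a double-bonded chain carbon bound to a double-bonded chain carbon and a saturated chain carbon gives a 1.8-fold lower number from compound 3 to compound 4 (0.26 log units; within the scatter) in this assay. For the compounds shown here, this is the first step read at this position, and the two groups cannot be told apart by this read-out. Nothing measured bears on why the two compounds read as they do. The compounds shown leave open how a plain phenyl at this position would read on the core of compound 3. They also leave open whether a methoxy group or an amine on that ring would give a different number.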